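Naphthylpyridine amides: azetidine to methylpiperazine step

The compounds below may be only part of what the source reports. "The series", "measured", "known", "first", "only" and "open" are said of these compounds alone.

Measured compounds:
compound 1 `COC1CN(C(=O)/C=C/c2ccncc2-c2ccc3ccccc3c2)C1`, > 10000 nM
compound 2 `CNC(=O)CCc1ccncc1-c1ccc2ccccc2c1`, > 10000 nM

In a functional assay on MCF7 cells (Homo sapiens) for inhibition, read by sulforhodamine B assay, with a stated time of 72 h (on this read-out higher numbers stand for weaker inhibition of growth and lower numbers for stronger inhibition of growth), compound 1 gives only a limit, > 10000 nM. Compound 2 likewise gives only a limit, > 10000 nM. Both values sit at the limit of > 10000 nM in this assay, at which 2 of the 2 values shown sit, so compound 1 stands at the ceiling of the numbers shown and no real step between measured compounds exists.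

Compound 3 `CN1CCN(C(=O)/C=C/c2ccncc2-c2ccc3ccccc3c2)CC1` carries 4-methylpiperazin-1-yl in place of 3-methoxyazetidin-1-yl on a carbonyl carbon. Within the data shown here, with both neighbours at the limit and no measured step to point to, no move beyond the scatter is expected in this assay. Compound 3 is therefore estimated to remain at the limit, around 15000 nM (range 4000 nM to 50000 nM). The expected step is a step that the limit leaves unreadable from compound 1 to compound 3.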

Compound 3, concentration for 50% growth inhibition: > 10000 nM
Compound 3 was reported as a limit; the forecaster's own chance of this, stated with the estimate: 75%; the middle value does not contradict the limit.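

In this assay compound 3 gives > 10000 nM, a limit, so no step from compound 1 to compound 3 can be read: the limit of > 10000 nM in this assay, at which 3 of the 3 values shown sit.

The compounds shown leave open whether any change to this series yields a measurable growth inhibition value.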